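The source may hold more compounds than are shown below. What is called first, only, known or untested is meant among the compounds shown, and "the series" means these compounds.

Working notes on the series in a physicochemical assay for metabolic stability, read by LC-MS, in phosphate buffer, with a stated time of 3 h, at pH 7.4, tested at 50 uM; a lower number here means that less of the compound is left, a higher number that more of the compound is left. Compound 1 `CC(C)C(=O)OCOC(=O)C1=C(S[C@@H]2CN[C@H](C(=O)Nc3cccc(C(=O)OCOC(=O)C(C)C)c3)C2)[C@H](C)[C@@H]2[C@@H]([C@@H](C)O)C(=O)N12` reaches only the limit of this assay, > 95%. Compound 2 `CCOC(=O)c1cccc(NC(=O)[C@@H]2C[C@H](SC3=C(C(=O)O)N4C(=O)[C@H]([C@@H](C)O)[C@H]4[C@H]3C)CN2)c1` likewise gives only a limit, > 95%. Compound 3 `C[C@@H](O)[C@H]1C(=O)N2C(C(=O)O)=C(S[C@@H]3CN[C@H](C(=O)Nc4cccc(C(=O)OCC(F)(F)F)c4)C3)[C@H](C)[C@H]12` also returns a limit, > 95%. Going by the values given here, the single measured step with one change, a step that the two limits leave unreadable from compound 2 to compound 3, is therefore unreadable in size, and compound 3 stands only as a limit among values that are all limits (the limit of > 95% in this assay, at which 3 of the 3 values shown sit). Compound 4 `CC(C)C(=O)OCOC(=O)c1cccc(NC(=O)[C@@H]2C[C@H](SC3=C(C(=O)O)N4C(=O)[C@H]([C@@H](C)O)[C@H]4[C@H]3C)CN2)c1` has not yet been run in this assay. It differs from compound 3 by (isopropylcarbonyl)oxy in place of trifluoromethyl on a saturated chain carbon bound to an oxygen next to a carbonyl group; cut one bond further out, the change reads 2,2,2-trifluoroethyl to ((isopropylcarbonyl)oxy)methyl. Compound 1 carries the same ((isopropylcarbonyl)oxy)methyl group and in this assay gives > 95%. No readable step bears on the change, so the expected step is a step that the limit leaves unreadable from compound 3 to compound 4, nothing beyond the scatter. Compound 4 is accordingly estimated at 96%, within a range of 90% to 100%, most probably again reported only as the limit.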

Compound 4, percent of the compound remaining: > 95%
Compound 4: no number, only a limit (the forecaster's own chance of this, stated with the estimate: 85%); the middle value does not contradict the limit.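

The steps from compound 1, compound 2 and compound 3 to compound 4 in this assay cannot be read, and no new step follows: the limit of > 95% in this assay, at which 4 of the 4 values shown sit.

The compounds shown leave open whether the groups varied here differ at all in this assay, where none of them gives a number.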